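Dichlorophenyl for dimethylphenyl on the shared core

The compounds below may be only part of what the source reports. "The series", "measured", "known", "first", "only" and "open" are said of these compounds alone.

In a functional assay on A549 cells (Homo sapiens) for antiproliferative activity, read by MTT assay, with a stated time of 48 h (a higher number here means a weaker inhibitor, a lower number a stronger inhibitor), compound 3 `Cc1ccc(C)c(-n2nncc2CN2C(=O)C3(C(C#N)=C(N)Oc4c3c3nc5ccccc5nc3c3ccccc43)c3ccccc32)c1` gives only a limit, > 50000 nM. Compound 1 `N#CC1=C(N)Oc2c(c3nc4ccccc4nc3c3ccccc23)C12C(=O)N(Cc1cnnn1-c1ccc(S(N)(=O)=O)cc1)c1ccccc12` gives a limit as well in this assay, > 50000 nM. Among the measured compounds shown here, compound 2 `N#CC1=C(N)Oc2c(c3nc4ccccc4nc3c3ccccc23)C12C(=O)N(Cc1cnnn1-c1cccc(S(N)(=O)=O)c1)c1ccccc12` gives 44200 nM in this assay, the one numeric value among the three. The step of an at least 1.1-fold higher number from compound 2 to compound 3 (0.05 log units; that floor lies within the scatter) lies within the scatter, and the step that the two limits leave unreadable from compound 1 to compound 3 cannot be read between the two limits; the limit of > 50000 nM in this assay, at which 2 of the 3 values shown sit, caps two of the three values, so compound 3 stands at the top of what this assay reports, with no reading above it.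

Compound 4 `N#CC1=C(N)Oc2c(c3nc4ccccc4nc3c3ccccc23)C12C(=O)N(Cc1cnnn1-c1cc(Cl)ccc1Cl)c1ccccc12` differs from compound 3 by 2,5-dichlorophenyl in place of 2,5-dimethylphenyl on an aromatic nitrogen. For the measured compounds named here, no measured step exchanges methyl for chlorine on this phenyl; the steps that reach compound 3 are an at least 1.1-fold higher number from compound 2 to compound 3 (0.05 log units; that floor lies within the scatter) and a step that the two limits leave unreadable from compound 1 to compound 3, one within the scatter and one unreadable. On that basis no step beyond the scatter is expected in this assay, in either direction, and a limit is the likeliest report. Compound 4 is expected at about 50000 nM in this assay, between 20000 nM and 150000 nM. The expected step of a number no higher from compound 3 to compound 4 (the limit leaves the size open) is therefore essentially none beyond the scatter.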

Compound 4, half-maximal inhibitory concentration: > 50000 nM
Compound 4: only a limit was reported; the forecaster's own chance of this, stated with the estimate: 65%; the middle value sits exactly at the limit.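

Replacing 2,5-dimethylphenyl with 2,5-dichlorophenyl on the aromatic nitrogen still gives no numeric reading in this assay: compound 4 gives > 50000 nM, which is a limit and not a number. The steps to compound 4 from compound 1 and from compound 3 cannot be read, as both ends of each are limits. The one readable step, an at least 1.1-fold higher number from compound 2 to compound 4 (0.05 log units; that floor lies within the scatter), separates 2,5-dichlorophenyl from 3-sulfamoylphenyl by nothing beyond the scatter, and the series now sits mostly at the cap: the limit of > 50000 nM in this assay, at which 3 of the 4 values shown sit.

From the compounds shown here alone, whether chlorine and methyl on this phenyl differ at all in this assay remains open. Also open, going by these compounds, is whether a phenyl carrying an amine or a carboxylic acid, or a longer chain in place of the phenyl, would give a number clear of the limit.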